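A Longer Methoxy Chain on the Amine Side

The source may report more compounds than this note shows. Statements on the series, on what has been measured and on what is new or still open speak of the compounds shown alone.

Of the compounds shown here, two have been measured in a functional assay on Caco-2 cells (Homo sapiens) for activation, read by fluorescence, tested at 10 uM; on this read-out lower numbers stand for a stronger effect and higher numbers for a weaker effect at the one concentration tested. Compound 1 `COCCCN1C(/C=C/c2ccc(O)cc2)=CC(=O)CC1c1ccc(O)cc1` gives 99.4% in this assay. Compound 2 `COCCNC(=C\C(=O)/C=C/c1ccc(O)cc1)/C=C/c1ccc(O)cc1` gives 89.7%, the lowest of the two numbers, yet its nearest neighbour, compound 1, lies within the usual scatter of it, so the two cannot be ranked against each other. Compound 3 `COCCCNC(=C\C(=O)/C=C/c1ccc(O)cc1)/C=C/c1ccc(O)cc1` has not yet been measured. It differs from compound 2 in a single place: methoxymethyl in place of methoxy on a saturated chain carbon, two bonds along the chain from an amine nitrogen. Among the measured compounds shown here, no step between two measured compounds is known, so there is nothing to show how a change of this kind moves the read-out; both measured numbers sit high on the scale and close together. Compound 3 is therefore expected to stay near compound 2, with a step of a number 2.3 percentage points higher from compound 2 to compound 3 (within the scatter) expected to fall within the scatter or only just beyond it. Compound 3 is estimated to read 92%, with a range from 80% to 102%, the chance of a limit instead of a number being small.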

Compound 3, a percentage reported as activity, at one concentration (the size of the read-out at that concentration, not a potency): 89%
Compound 3: middle estimate off by 3 percentage points, on the high side; the range from low to high includes it.
By their numbers in this assay, from the lowest: compounds 3, 2 and 1 (each within the scatter of the next, the first and the last beyond it).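

Among the compounds shown here, this is the first step that can be read at this position in this assay: methoxymethyl in place of methoxy on a saturated chain carbon, two bonds along the chain from an amine nitrogen, gives a number 0.7 percentage points lower from compound 2 to compound 3 (within the scatter). The (2-methoxyethyl)amino chain of compound 2 and the (3-methoxypropyl)amino chain of compound 3 therefore cannot be told apart on this read-out, although the entering group carries one more carbon and the count of hydrogen-bond donors and acceptors stays the same. Nothing available explains this result or bears on it in any other way.

A single step within the scatter, at one tested concentration, leaves open whether this position would stay as undemanding with a much longer chain, such as a 5-methoxypentyl group, or whether the read-out would move if the methoxy group gave way to an amine or a carboxylic acid. It also leaves open whether a compound of this series can reach a clearly lower number in this assay, since the step shown covers only a single added carbon on the chain.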